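Swapping thiophen-2-yl for pyridin-2-yl on a shared core

The source may report more compounds than this note shows. Statements on the series, on what has been measured and on what is new or still open speak of the compounds shown alone.

Going by the values given here, compound 1 `Oc1cccc(-c2cc(-c3cccs3)cc(-c3ccccc3O)n2)c1` is one of only two compounds measured so far in an assay on isolated protein for inhibition of DNA topoisomerase 1 (Homo sapiens), with a stated time of 30 min, tested at 100 uM (a lower number here means a weaker effect, a higher number a stronger effect of the compound at the concentration tested), where compound 1 gives 83.2%. The other is compound 2 `Oc1ccc(-c2cc(-c3cccs3)cc(-c3cccc(O)c3)n2)cc1`, which in this assay gives 85.7%. Among the compounds with values here, the single step between them, a number 2.5 percentage points higher from compound 1 to compound 2 (within the scatter), lies within the scatter, so compound 1 stands at the lower of two numbers that cannot be told apart.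

Compound 3 `Oc1cccc(-c2cc(-c3ccccn3)cc(-c3ccccc3O)n2)c1` has not yet been measured. It differs from compound 1 in one place: pyridin-2-yl in place of thiophen-2-yl on an aromatic carbon. Within the data shown here, no measured step touches this group; the one step that exists changes a different part of the molecule and stayed within the scatter. Among the measured compounds shown here, the only guide is that both measured numbers sit at a high level of inhibition. Compound 3 is therefore expected to stay near that level, with an expected step of a number 5.2 percentage points lower from compound 1 to compound 3 (within the scatter) that should not go beyond the scatter. The estimate for compound 3 in this assay is 78%, in a range from 58% to 92%.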

Compound 3, a percentage reported as inhibition, at one concentration (the size of the read-out at that concentration, not a potency): 35.4%
For compound 3 the middle estimate is 42.6 percentage points above the measured one, outside the stated range (below it).
By their numbers in this assay, from the lowest: compound 3; then compounds 1 and 2 (each within the scatter of the next).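

Unlike the one earlier step, which changed a hydroxyphenyl group and stayed within the scatter, this change shows that this assay responds strongly to the group opposite the ring nitrogen of the shared core. Pyridin-2-yl in place of thiophen-2-yl gives a number 47.8 percentage points lower from compound 1 to compound 3 (beyond the scatter) and so takes away much of the high inhibition seen for compound 1, even though the two groups have the same counts of hydrogen-bond donors and acceptors and differ in ring size and in carrying nitrogen rather than sulfur. No measurement shown here explains the drop or separates the contribution of ring size from that of the hetero atom.

The compounds shown leave open whether a plain phenyl ring, furan-2-yl or thiophen-3-yl at this place would keep the level of compound 1, and whether moving the ring nitrogen within the pyridine, as in pyridin-3-yl, would recover any of the loss. They also leave open whether the same exchange on compound 2, with its 4-hydroxyphenyl group, would produce a step of similar size.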